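Swapping a Carbamoyl for a Chloro at the Aniline

The source may report more compounds than this note shows. Statements on the series, on what has been measured and on what is new or still open speak of the compounds shown alone.

Compound 1 `CCOc1ccc(Br)cc1-c1cc(Nc2ccc(C(N)=O)cc2)nc(N)n1` is a small molecule tested in an assay on Sf9 cells for inhibition of 1-acyl-sn-glycerol-3-phosphate acyltransferase beta (Homo sapiens) (on this read-out higher numbers stand for weaker inhibition and lower numbers for stronger inhibition), where compound 1 gives 750 nM. Among the compounds with values here, of the two numbers known so far this is the highest. The other measured compound, compound 2 `CCOc1ccc(Cl)cc1-c1cc(Nc2ccc(CCCO)cc2)nc(N)n1`, gives 230 nM in this assay, a number lower than that of compound 1 by more than the usual scatter; the two compounds differ in more than one place, so the gap between them cannot be tied to a single change.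

Compound 3 `CCOc1ccc(Br)cc1-c1cc(Nc2ccc(Cl)cc2)nc(N)n1` has not yet been measured. It differs from compound 1 in one place: chloro in place of carbamoyl on an aromatic carbon. Within the data shown here, nothing measured so far isolates this change, so the expectation rests only on the numbers of compound 1 and compound 2. The estimated step from compound 1 to compound 3 is a 1.3-fold lower number from compound 1 to compound 3 (0.10 log units; within the scatter), expected to stay within the scatter, in either direction. Compound 3 is therefore expected to give about 600 nM in this assay, with a likely range from 150 nM to 2500 nM.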

Compound 3, half-maximal inhibitory concentration: 16 nM
Compound 3: the middle estimate sits 38-fold (1.57 log units) above what was measured; measured number outside the range, below it.
By their numbers in this assay, from the lowest: compound 3; then compound 2; then compound 1.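

Within the data shown here, until now, no pair of compounds isolated a single change, so it was unclear how much the group on this aromatic carbon, para to a large group, matters in this assay. Replacing carbamoyl with chloro here gives a 47-fold lower number from compound 1 to compound 3 (1.67 log units; beyond the scatter), with the rest of the molecule unchanged, so this one position alone can shift the number strongly. The swap replaces three heavy atoms, including a hydrogen-bond donor and acceptor, with a single chlorine that has neither, which shows that strong inhibition in this pair does not require carbamoyl, but no measurement available here explains why the number falls so far.

This single pair cannot separate a gain from adding chloro from a gain from removing carbamoyl, and a fluoro, a methyl, a methoxy or an amine on the same carbon would help tell those two readings apart. As far as these compounds go, it also remains open whether the same swap gives a similar step in a compound carrying a different halogen in place of the bromo group.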